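Fluoro in place of chloro: compound 2 to compound 4

The source may report more compounds than this note shows. Statements on the series, on what has been measured and on what is new or still open speak of the compounds shown alone.

Measured compounds, all in a functional assay on the whole organism for activation, with Mus musculus as the target, with a stated time of 60 min; on this read-out lower numbers stand for an effect already at smaller amounts and higher numbers for an effect only at larger amounts of compound
- compound 1 `O=C1NC(=O)N(/N=C/c2ccc(-c3ccc(Cl)c(Cl)c3)o2)C1O` gives 72 mg/kg
- compound 2 `O=C1NC(=O)N(/N=C/c2ccc(-c3ccc(Cl)cc3)o2)C1O` gives > 1000 mg/kg (a limit)
- compound 3 `CC(=O)Nc1ccc(-c2ccc(/C=N/N3C(=O)NC(=O)C3O)o2)cc1` gives > 1000 mg/kg (a limit)

Compound 2 stands at > 1000 mg/kg, which is a limit of the assay and not a number. Compound 3 also gives only a limit. The series is marked by the limit of > 1000 mg/kg in this assay, at which 2 of the 3 values shown sit, and compound 1 alone carries a number.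

Compound 4 `O=C1NC(=O)N(/N=C/c2ccc(-c3ccc(F)cc3)o2)C1O` is still unmeasured. The change from compound 2 to compound 4 fluoro in place of chloro on an aromatic carbon is fluoro in place of chloro on an aromatic carbon, para to a large group.

Among the compounds with values here, two measured steps bear on this change, and neither involves fluoro. The large step of an at least 13-fold higher number from compound 1 to compound 2 (1.14 log units; beyond the scatter) comes with hydrogen in place of chloro on an aromatic carbon. The step that the two limits leave unreadable from compound 2 to compound 3 comes with acetamido in place of chloro on an aromatic carbon, and it has no readable size.

Compound 4 is therefore expected to stay close to the limit of compound 2, with no clear move towards compound 1, and a further report of a limit is quite likely. In this assay the expected step is a number no higher from compound 2 to compound 4 (the limit leaves the size open), and it cannot be read with confidence in either direction. For compound 4 the estimated value is 1000 mg/kg, with an expected range from 350 mg/kg to 3000 mg/kg.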

Compound 4, dose for half-maximal effect: 1000 mg/kg
For compound 4 middle estimate and measured number coincide at the digits printed, and the stated range covers the measured number.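

In this assay compound 4 gives 1000 mg/kg, a number and not a limit, and among the compounds shown it is the only one with a single group on the six-membered aromatic ring to do so. Compound 2 gives > 1000 mg/kg, which is a limit. The change from chloro to fluoro at this position brings a number no higher from compound 2 to compound 4 (the limit leaves the size open), and the change from acetamido to fluoro at this position brings a number no higher from compound 3 to compound 4 (the limit leaves the size open). Neither step has a readable size, because each starts from a limit: the limit of > 1000 mg/kg in this assay, at which 2 of the 4 values shown sit.

Still open, going by these compounds, is how an amine, a methoxy group or a carboxylic acid in the same place, para to a large group, would read in this assay, which would show whether values at this position can move well away from the limit. Also open, on these data alone, is whether a second fluoro on the ring of compound 4 would bring a step like the one seen for the second chloro, an at least 13-fold higher number from compound 1 to compound 2 (1.14 log units; beyond the scatter).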